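Inverting one ring stereocentre of compound 1

The source may hold more compounds than are shown below. What is called first, only, known or untested is meant among the compounds shown, and "the series" means these compounds.

Compound 1 `O=C(O)[C@H]1NCC=C[C@@H]1O` gives the higher number of the two measured compounds: in an assay on isolated protein for inhibition of cytosolic endo-beta-N-acetylglucosaminidase (Homo sapiens), tested at 1000 uM (on this read-out lower numbers stand for less inhibition and higher numbers for more inhibition at the one concentration tested (going by the name of the read-out)), compound 1 gives 60%, while compound 2 `O=C(O)[C@H]1NC[C@H](O)[C@H](O)[C@H]1O` gives 7.6%, a gap beyond the usual scatter. Compound 3 `O=C(O)[C@H]1NCC=C[C@H]1O` has not yet been measured. Relative to compound 1 the change is the two compounds have the same atoms and bonds and differ only in configuration as drawn: 1 of 2 stereo elements differ; a stereocentre at a saturated ring carbon is drawn S in compound 1 and R in compound 3. Within the data shown here, no step between measured compounds bears on such an inversion, so its size is not known; a drop in this assay is expected, of roughly the size of the scatter or somewhat more. For compound 3 the estimate is 35%, within 5% to 70%, an expected step of a number 25 percentage points lower from compound 1 to compound 3 (beyond the scatter).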

Compound 3, a percentage reported as inhibition, at one concentration (the size of the read-out at that concentration, not a potency): 17%
For compound 3 the middle estimate is 18 percentage points above the measured one; low and high end bracket the measured number.
By their numbers in this assay, from the lowest: compounds 2 and 3 (each within the scatter of the next); then compound 1.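

Inverting this saturated ring carbon gives a number 43 percentage points lower from compound 1 to compound 3 (beyond the scatter) in this assay and so shows that the S configuration drawn in compound 1 matters at this position, which no earlier step could show. The step can be assigned to this one stereocentre alone because of a single fact: the fact that compounds 1 and 3 differ only in the configuration as drawn.

On these data alone, whether the other stereocentre is equally sensitive remains open. Also open, as far as these compounds go, is whether a methyl ester in place of the carboxylic acid would keep the read-out at the level of compound 1.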